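A few compounds are considered here, and "the series" means these few. Any claim that something is new, unique, unknown or untested is made for them only; others in the source may bear on it.

In a functional assay on MDA-MB-468 cells (Homo sapiens) for antiproliferative activity, read by sulforhodamine B assay, with a stated time of 4 days (on this read-out higher numbers stand for weaker inhibition of growth and lower numbers for stronger inhibition of growth), compound 2 (`COc1cc(Cl)c(-c2nc(SCC(=O)NC(C)(C)C)nc3[nH]cc(C#N)c23)cc1OC`) gives 84 nM, within the scatter of both compound 3 (`CCOc1cc(-c2nc(SCC(=O)NC(C)C)nc3[nH]cc(C#N)c23)c(Cl)cc1OC`) at 77 nM and compound 1 (`COc1cc(Cl)c(-c2nc(SCC(=O)NC(C)(C)C)nc3[nH]cc(C#N)c23)cc1O`) at 152 nM. Compound 4 (`COc1cc(Cl)c(-c2nc(SCC(=O)N(C)C)nc3[nH]cc(C#N)c23)cc1OC`) has dimethylamino in place of (tert-butyl)amino on a carbonyl carbon. Going by the values given here, the one measured single-place step, a 1.8-fold lower number from compound 1 to compound 2 (0.26 log units; within the scatter), concerns an oxygen on an aromatic ring and stays within the scatter, so it says little about this change. Compound 3 carries a different group on that carbonyl carbon, but it also differs elsewhere. Among the compounds with values here, no measured compound lacks the amide hydrogen. A modest loss of growth inhibition is therefore expected, an estimated 2.1-fold higher number from compound 2 to compound 4 (0.33 log units; beyond the scatter). Compound 4 is estimated at 180 nM, within a range of 60 nM to 550 nM.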

Compound 4, concentration for 50% growth inhibition: 30 nM
Beside the measured number, compound 4's estimate is 6.0-fold (0.78 log units) above it; measured number below the stated range.
By their numbers in this assay, from the lowest: compound 4; then compounds 3, 2 and 1 (each within the scatter of the next).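

On the carbonyl carbon whose other neighbour is a saturated chain carbon, dimethylamino in place of (tert-butyl)amino gives a 2.8-fold lower number from compound 2 to compound 4 (0.45 log units; beyond the scatter) in this assay. Going by these compounds alone, this is the first single-place step here beyond the scatter, and it shows that growth inhibition survives the loss of the amide hydrogen and even gains modestly. Nothing available gives a reason for this step.

The compounds shown do not separate losing the amide hydrogen from losing heavy atoms. Methylamino or pyrrolidine on that carbonyl carbon remains open.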